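Ester Branching Beside an Adenosine Receptor Hit

The source may report more compounds than this note shows. Statements on the series, on what has been measured and on what is new or still open speak of the compounds shown alone.

Compound 1 `CC1=C(C(=O)OCC(C)C)C(c2cccs2)NC(=O)N1` stands highest of three compounds in an assay on membranes from CHO cells for displacement of a labelled ligand from adenosine receptor A1 (Homo sapiens), read by scintillation counting, with a stated time of 60 min, tested at 1 uM (on this read-out higher numbers stand for more inhibition at the one concentration tested (going by the name of the read-out) and lower numbers for less inhibition), where compound 1 gives 25%. Going by the values given here, its nearest neighbour is compound 3 `CC1=C(C(=O)OCC(C)C)C(c2cccs2)NC(=O)N1C`, which in this assay gives 9%; the one step between them, a number 16 percentage points lower from compound 1 to compound 3 (beyond the scatter), comes from methyl in place of hydrogen on an amide-type nitrogen in a ring. Compound 2 `CC1=C(C(=O)OC(C)(C)C)C(c2ccco2)NC(=S)N1` gives 3% in this assay, but it differs from compound 1 in several places at once, so its value speaks only for itself.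

Compound 4 `CCC(CC)OC(=O)C1=C(C)NC(=O)NC1c1cccs1` is not yet measured. It differs from compound 1 by pentan-3-yl in place of isobutyl on an oxygen next to a carbonyl group. Among the compounds with values here, no measured step touches the ester side chain: the only step in hand concerns the ring nitrogen, and compound 2 offers no single-point comparison. One alkyl chain replaces another of similar size on the same oxygen, so the expected change is none beyond the scatter, with wide uncertainty. Compound 4 is therefore expected to give about 22%, within 6% to 40%, an expected step of a number 3 percentage points lower from compound 1 to compound 4 (within the scatter).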

Compound 4, a percentage reported as inhibition, at one concentration (the size of the read-out at that concentration, not a potency): 13%
The estimate for compound 4 lay 9 percentage points above the measured number, within the range that was stated.
By their numbers in this assay, from the lowest: compounds 2, 3 and 4 (each within the scatter of the next); then compound 1.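

The ester side chain is not a silent position: in this assay, exchanging one alkyl group for another on an oxygen next to a carbonyl group gives a number 12 percentage points lower from compound 1 to compound 4 (beyond the scatter). Going by these compounds alone, until now the only single-place step concerned the ring nitrogen, so this is the first sign that the number also responds to the group on this oxygen, even when isobutyl gives way to a chain only slightly larger. Both single-place steps now shown lead downward from compound 1, and nothing available explains the drop seen with pentan-3-yl.

On these data alone, whether a shorter chain such as ethyl, or a ring such as cyclopentyl or benzyl, on this oxygen would keep or raise the number remains open. So does whether pentan-3-yl would act the same way on a core carrying a furan or a thiocarbonyl.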